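The source may report more compounds than this note shows. Statements on the series, on what has been measured and on what is new or still open speak of the compounds shown alone.

Compound 1 `O=c1nc(N2CCN(NCC3CCCCC3)CC2)sc2c([N+](=O)[O-])cc(C(F)(F)F)cc12` was tested in an ADME assay on Vero cells (Chlorocebus sabaeus) for cytotoxicity, read by MTT assay, with a stated time of 72 h (on this read-out lower numbers stand for higher toxicity in this test and higher numbers for lower toxicity in this test), where compound 1 gives 29.3 ug/mL. Compound 2 `CN(CC1CCCCC1)N1CCN(c2nc(=O)c3cc(C(F)(F)F)cc([N+](=O)[O-])c3s2)CC1` carries methyl in place of hydrogen on an amine nitrogen. In this assay compound 2 reaches only the limit of the assay, reported as > 64 ug/mL. The step of an at least 2.1-fold higher number from compound 1 to compound 2 (0.33 log units; beyond the scatter) thus runs toward lower toxicity, and it rests on (the limit of > 64 ug/mL in this assay, at which 2 of the 3 values shown sit). Compound 3 `CC(NN1CCN(c2nc(=O)c3cc(C(F)(F)F)cc([N+](=O)[O-])c3s2)CC1)c1ccc(OC(F)(F)F)cc1` is built on the same core, but the difference between the two cores is not broken down here. In this assay compound 3 gives only the limit > 64 ug/mL. Compound 4 `CC(c1ccc(OC(F)(F)F)cc1)N(C)N1CCN(c2nc(=O)c3cc(C(F)(F)F)cc([N+](=O)[O-])c3s2)CC1` has not yet been measured; it differs from compound 3 by methyl in place of hydrogen on an amine nitrogen, the same change as from compound 1 to compound 2, at a place described in the same words. For compound 4 the step that the limit leaves unreadable from compound 3 to compound 4 in this assay is expected, and it is expected because compound 3 already sits at the limit of > 64 ug/mL in this assay, at which 2 of the 3 values shown sit, and the earlier change an at least 2.1-fold higher number from compound 1 to compound 2 (0.33 log units; beyond the scatter) moved in the direction of that limit. The value of compound 4 in this assay is estimated at 80 ug/mL, with a range from 45 ug/mL to 150 ug/mL, most likely reported again as a limit.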

Compound 4, half-maximal cytotoxic concentration: > 64 ug/mL
Compound 4 gave a limit, no number; the forecaster's own chance of this, stated with the estimate: 85%; the middle value lies beyond the limit too.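

In this assay, compound 3 and compound 4 both give a limit and no number, so no step can be read between them, because both sit at the same limit: the limit of > 64 ug/mL in this assay, at which 3 of the 4 values shown sit.

The compounds shown leave open how far methyl in place of hydrogen on an amine nitrogen shifts the read-out from compound 3 to compound 4, or whether it shifts it at all.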